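Closing a basic side chain into a ring

A few compounds are considered here, and "the series" means these few. Any claim that something is new, unique, unknown or untested is made for them only; others in the source may bear on it.

Measured compounds:
compound 1, `CO[C@@H]1C[C@@H](C(=O)NCCN(C)C)N(C(=O)NCc2ccc(C(=O)N3CCCCc4sccc43)cc2Cl)C1`, > 10000 nM;
compound 2, `Cc1cc(C(=O)N2CCCCc3sccc32)ccc1CNC(=O)N1CCC[C@H]1C(=S)N1CCCN(C)CC1`, 640 nM;
compound 3, `CN1CCCN(C(=S)[C@@H]2CCCN2C(=O)NCc2ccc(C(=O)N3CCCCc4sccc43)cc2Cl)CC1`, 810 nM.

The read-out throughout is an assay on isolated protein with Oxytocin receptor (Homo sapiens) as the target; on this read-out higher numbers stand for an effect only at larger amounts of compound and lower numbers for an effect already at smaller amounts. For compound 1 the value is a limit of the assay, not a number: the compound showed no effect up to that amount (the limit of > 10000 nM in this assay, at which 1 of the 3 values shown sits). Compound 2 and compound 3 differ in one place only, chloro in place of methyl on an aromatic carbon, and the step is a 1.3-fold higher number from compound 2 to compound 3 (0.10 log units; within the scatter).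

The unmeasured compound 4, `CO[C@@H]1C[C@@H](C(=O)N2CCCN(C)CC2)N(C(=O)NCc2ccc(C(=O)N3CCCCc4sccc43)cc2Cl)C1`, keeps the core of compound 1 and changes the group on the carbonyl carbon: 4-methyl-1,4-diazepan-1-yl in place of (2-(dimethylamino)ethyl)amino on a carbonyl carbon. Among the measured compounds shown here, no measured step covers this change; the single step between compound 2 and compound 3 concerns a substituent on the aromatic ring and says nothing about the side chain. What the data do show is that the 4-methyl-1,4-diazepan-1-yl group, on a different core, appears in compound 2 and compound 3, both of which give measurable values, while compound 1 with the open-chain group sits at the limit. Compound 4 is therefore expected to move below the limit, a step of an at least 4.0-fold lower number from compound 1 to compound 4 (0.60 log units; beyond the scatter), with an estimate of 2500 nM in a range from 600 nM to 10000 nM.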

Compound 4, half-maximal effective concentration: 2800 nM
Compound 4: the middle estimate sits 1.1-fold (0.05 log units) below what was measured; low and high end bracket the measured number.
By their numbers in this assay, from the lowest: compounds 2 and 3 (each within the scatter of the next); then compound 4. At a limit, above all of these: compound 1.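

In this assay, replacing the open (2-(dimethylamino)ethyl)amino group on the carbonyl carbon with the 4-methyl-1,4-diazepan-1-yl group gives an at least 3.5-fold lower number from compound 1 to compound 4 (0.55 log units; beyond the scatter). This is the first step shown at this position with the rest of the molecule held constant, and it shows that the group here can move the read-out from a limit to a measurable number. The size of the step remains a minimum because compound 1 carries a limit of the assay, not a number: the limit of > 10000 nM in this assay, at which 1 of the 4 values shown sits.

The compounds shown leave open whether the seven-membered ring or the change from 1 hydrogen-bond donor to 0 accounts for the step, since both arrive together; an open chain with a methyl group on the amide nitrogen, or a 4-methylpiperazin-1-yl group on the same carbonyl carbon, would separate the two. They also leave open how compound 4 relates to compound 2 and compound 3, as it differs from each of them in more than one place.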